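Nitro for fluoro on the aryl imine: cytotoxicity outlook

The source may report more compounds than this note shows. Statements on the series, on what has been measured and on what is new or still open speak of the compounds shown alone.

Measured so far in an ADME assay on cells (Rhabdomyosarcoma cell, Homo sapiens) for cytotoxicity, read by MTT assay, with a stated time of 72 h; a lower number here means that less compound is tolerated, a higher number that more compound is tolerated:
- compound 1 `Fc1ccccc1/C=N/c1sc2c(c1-c1nc3ccccc3s1)CCC2` gives 270 ug/mL
- compound 2 `C(=C/c1ccccc1)\C=N\c1sc2c(c1-c1nc3ccccc3s1)CCC2` gives 122 ug/mL
- compound 3 `Fc1ccc(/C=N/c2sc3c(c2-c2nc4ccccc4s2)CCCC3)cc1` gives 230 ug/mL

Compound 3 stands second highest of the three numbers; compound 1 lies within the scatter of it, and compound 2 also lies within the scatter, so none of the three can be ranked against the others on these values alone. The only step shown, a 2.2-fold lower number from compound 1 to compound 2 (0.35 log units; beyond the scatter), exchanges the whole aryl group for a phenylethenyl group on the core shared by compound 1 and compound 2, and is modest.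

Compound 4 `O=[N+]([O-])c1ccc(/C=N/c2sc3c(c2-c2nc4ccccc4s2)CCCC3)cc1` differs from compound 3 by nitro in place of fluoro on an aromatic carbon. Going by the values given here, no measured pair shows a fluoro-to-nitro exchange, and the one measured step concerns a different replacement on a different core, so it bears on the present change only as a gauge of how far a change at this position has moved the number so far. The expectation for this assay is therefore a step of at most modest size, its direction not fixed by the data: no change at the digits printed from compound 3 to compound 4 (within the scatter). Compound 4 is estimated at 230 ug/mL, with a range from 115 ug/mL to 460 ug/mL.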

Compound 4, half-maximal cytotoxic concentration: 316 ug/mL
Compound 4: the middle estimate sits 1.4-fold (0.14 log units) below what was measured; the range from low to high includes it.
By their numbers in this assay, from the lowest: compounds 2, 3, 1 and 4 (each within the scatter of the next, the first and the last beyond it).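

In this assay, the exchange of 4-fluorophenyl for 4-nitrophenyl gives a 1.4-fold higher number from compound 3 to compound 4 (0.14 log units; within the scatter), so compound 3 and compound 4 cannot be told apart on these values, even though nitro brings more heavy atoms and hydrogen-bond acceptors to this aromatic carbon, para to a large group, than fluoro does. The earlier step, a 2.2-fold lower number from compound 1 to compound 2 (0.35 log units; beyond the scatter), replaced the whole aryl group on another core and lay beyond the scatter, whereas this first step on the core of compound 3 keeps the aryl group and alters only the group on it. No measured evidence bears on why the step stays this small.

The compounds shown leave open whether an amine or a carboxylic acid at the same place would move the number beyond the scatter, or would again stay within it. Going by these compounds, one pair on one core also sets no rule for this position, and whether 4-nitrophenyl in place of 4-fluorophenyl on the core of compound 1 would give a step of similar size remains open.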